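The source may hold more compounds than are shown below. What is called first, only, known or untested is meant among the compounds shown, and "the series" means these compounds.

Compound 2 `COc1cc(C(=O)c2ccc3c(ccn3C)c2)cc(OC)c1OC` is the stronger of the two compounds measured with a number in a functional assay on TSGH cells (Homo sapiens) for inhibition, with a stated time of 72 h; a higher number here means a weaker inhibitor, a lower number a stronger inhibitor: compound 2 gives 13.4 nM, while compound 1 `COc1cc(C(=O)c2cccc3cc[nH]c23)cc(OC)c1OC` gives 310 nM. Compound 3 `COc1cc(C(=O)c2ccc3c(ccn3CCC(=O)O)c2)cc(OC)c1OC` reaches only the limit of this assay, > 10000 nM. That change sits at the same place as the one considered here: an at least 740-fold higher number from compound 2 to compound 3 (2.87 log units; beyond the scatter), and the limit of > 10000 nM in this assay, at which 1 of the 3 values shown sits, is all that is known of it. Compound 4 `COc1cc(C(=O)c2ccc3c(ccn3CCN(C)C)c2)cc(OC)c1OC` differs from compound 2 by (dimethylamino)methyl in place of hydrogen on a saturated chain carbon bound to an aromatic nitrogen. Among the compounds with values here, the one measured step at this position was a large loss, though with a different group entering, so a weaker, not a larger, loss is expected: a 9.0-fold higher number from compound 2 to compound 4 (0.95 log units; beyond the scatter). Compound 4 is therefore estimated at 120 nM, between 20 nM and 1500 nM.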

Compound 4, half-maximal inhibitory concentration: 4900 nM
Compound 4: the middle estimate sits 41-fold (1.61 log units) below what was measured; the measured number lies above the stated range.
By their numbers in this assay, from the lowest: compound 2; then compound 1; then compound 4. At a limit, above all of these: compound 3.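

The large loss at this position is not confined to the carboxylic acid of compound 3: replacing methyl with 2-(dimethylamino)ethyl also costs heavily (a 370-fold higher number from compound 2 to compound 4 (2.56 log units; beyond the scatter)). The step between the two longer chains (an at least 2.0-fold lower number from compound 3 to compound 4 (0.30 log units; that floor lies within the scatter)) has a floor within the scatter, so it places them in no order. Compound 3 has only a limit, not a number: the limit of > 10000 nM in this assay, at which 1 of the 4 values shown sits.

The compounds shown leave open whether the loss follows the longer chain itself or the amine and acid at its end. A plain ethyl or propyl group, or a 2-hydroxyethyl chain, could separate these two readings.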